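Dichlorophenyl in Place of Phenyl on an Indole Piperazine

The compounds below may be only part of what the source reports. "The series", "measured", "known", "first", "only" and "open" are said of these compounds alone.

Of the compounds shown here, two have been measured in an assay on CHO cells for displacement of a labelled ligand from D(4) dopamine receptor (Homo sapiens); on this read-out higher numbers stand for weaker inhibition and lower numbers for stronger inhibition. Compound 1, `N#Cc1ccc2[nH]cc(CN3CCN(c4ccc(Cl)cc4)CC3)c2c1`, gives 29 nM in this assay. Compound 2, `N#Cc1ccc2cc(CN3CCN(c4ccccc4)CC3)[nH]c2c1`, gives 3.6 nM in this assay, the lower of the two numbers and therefore the stronger binder of the pair; the two compounds differ in more than one place, so their values are only compared, not read as a single step.

Compound 3, `N#Cc1ccc2cc(CN3CCN(c4ccc(Cl)c(Cl)c4)CC3)[nH]c2c1`, has not yet been measured. Its change from compound 2 is 3,4-dichlorophenyl in place of phenyl on an amine nitrogen in a ring. Within the data shown here, no measured pair in this set isolates this change, so the direction cannot be read from the data in hand; the expectation is for a step that stays near the scatter, with no strong movement in either direction, expressed as a 1.7-fold higher number from compound 2 to compound 3 (0.22 log units; within the scatter). On that basis compound 3 is estimated to give about 6 nM in this assay, with the likely range running from 1.5 nM to 25 nM.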

Compound 3, inhibition constant: 9 nM
Beside the measured number, compound 3's estimate is 1.5-fold (0.18 log units) below it; the range from low to high includes it.
By their numbers in this assay, from the lowest: compound 2; then compound 3; then compound 1.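

On the amine nitrogen in the six-membered ring with two nitrogens, 3,4-dichlorophenyl in place of phenyl gives a 2.5-fold higher number from compound 2 to compound 3 (0.40 log units; beyond the scatter) in this assay. Among these compounds, this is the first single change in the set that can be read on its own, and it shows that this position responds to what it carries, with the two added chlorine atoms bringing a modest loss of binding rather than a gain. The loss is limited, as compound 3 still gives 9 nM with the rest of the molecule unchanged, but nothing at hand explains this step.

Both chlorine atoms enter together, so the compounds shown cannot tell whether one of them alone would give the same step, or how much each contributes on the core of compound 2. Also open, from the compounds shown here alone, is how this position would respond to other groups on the phenyl ring, such as a single fluorine atom or a methoxy group, or to a pyridine ring in place of the phenyl.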